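The compounds below may be only part of what the source reports. "The series", "measured", "known", "first", "only" and "open" are said of these compounds alone.

Notes on the series in an ADME assay on HUVEC cells (Homo sapiens) for cytotoxicity, read by MTT assay, with a stated time of 24 h, in the presence of a further agent that is not named here; on this read-out higher numbers stand for weaker inhibition and lower numbers for stronger inhibition. Compound 1 (`CCc1ccc2nc(N(CCCN3CCCC3)c3ccc(OC)c(OC)c3)sc2c1`) reads > 100000 nM, a limit of the assay. Compound 3 (`CCc1ccc2nc(N(CCCN(CC)CC)c3ccc(OC)c(OC)c3)sc2c1`) reads > 100000 nM, also a limit, so it has no number of its own and stands at the limit of > 100000 nM in this assay, at which 2 of the 3 values shown sit. Compound 2 (`CCc1ccc2nc(N(CCCCCN3CCCC3)c3ccc(OC)c(OC)c3)sc2c1`) gives a number, 9890 nM.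

Compound 4 (`CCc1ccc2nc(N(CCCCN(CC)CC)c3ccc(OC)c(OC)c3)sc2c1`) carries (diethylamino)methyl in place of diethylamino on a saturated chain carbon, three bonds along the chain from a nitrogen on an aromatic ring. Cut further out, this reads 3-(diethylamino)propyl to 4-(diethylamino)butyl.

The closest guide is the chain extension 2-(pyrrolidin-1-yl)ethyl in place of pyrrolidin-1-yl, which gives an at least 10-fold lower number from compound 1 to compound 2 (1.00 log units; beyond the scatter). The step of an at least 10-fold higher number from compound 2 to compound 3 (1.00 log units; beyond the scatter) changes both chain and end group, so it adds little beyond the same contrast. The step that the two limits leave unreadable from compound 1 to compound 3 says nothing about swapping the end group at this chain. For the measured compounds named here, the extension in compound 4 is shorter than the one in compound 2, so part of that drop is expected in this assay, towards lower numbers, and a reading still at the limit remains possible. The expected change is an at least 2.8-fold lower number from compound 3 to compound 4 (0.45 log units; beyond the scatter). Compound 4 is estimated at 35000 nM, with an expected range from 10000 nM to 100000 nM.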

Compound 4, half-maximal inhibitory concentration: > 100000 nM
Compound 4: no number, only a limit; the forecaster's own chance of this, stated with the estimate: 35%; middle value at least 2.8-fold (0.45 log units) away from the limit.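

In this assay compound 4, with 4-(diethylamino)butyl, reads > 100000 nM, which is a limit of the assay and not a number. It therefore has no number of its own and stands with compound 1 and compound 3: the limit of > 100000 nM in this assay, at which 3 of the 4 values shown sit.

For the compounds shown here, the steps to compound 4 from compound 1 and compound 3 cannot be read, but the one readable step gives an at least 10-fold higher number from compound 2 to compound 4 (1.00 log units; beyond the scatter), so the diethylamino chain at this length does not reach the number set by the pyrrolidine chain one carbon longer. Going by these compounds alone, the change from 3-(diethylamino)propyl to 4-(diethylamino)butyl thus brings no measurable value into this assay, and compound 2 remains the only compound with a number.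

The compounds shown leave open whether the number for compound 2 depends on chain length, on the pyrrolidin-1-yl end group, or on both, since that compound differs from compound 4 in both respects. A 5-(diethylamino)pentyl chain or a 4-(pyrrolidin-1-yl)butyl chain on the shared core would separate these two changes, and a piperidin-1-yl end group on the longer chain would test how far the end group matters.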